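Working notes: tert-butyl for cyclopropyl, compound 1 to compound 4

This account rests on a few compounds, and the source may have more. Where it says the series, first, only, none or still open, it means among the compounds named here.

Measured so far:
compound 1 `c1ccc(/C(=N/Nc2nc3ccccc3o2)C2CC2)nc1`: 20600 nM
compound 2 `C/C(=N\Nc1nc2ccccc2o1)c1cnccn1`: 340 nM
compound 3 `C/C(=N\Nc1nc2ccccc2o1)c1cccnc1`: > 100000 nM, a limit of the assay and not a number

All three were read in a functional assay on HT-29 cells (Homo sapiens) for antiproliferative activity, read by sulforhodamine B assay; on this read-out higher numbers stand for weaker inhibition and lower numbers for stronger inhibition. Of the two numbers given, compound 1 stands highest; compound 2 sits clearly below it, beyond the scatter. Compound 3 gives only a limit, (the limit of > 100000 nM in this assay, at which 1 of the 3 values shown sits), and so cannot be placed against compound 1.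

Compound 4 `CC(C)(C)/C(=N\Nc1nc2ccccc2o1)c1ccccn1` is not yet measured. It differs from compound 1 in one place: tert-butyl in place of cyclopropyl on a carbon with a double bond to nitrogen.

Among the measured compounds shown here, the only measured step in this set, an at least 290-fold higher number from compound 2 to compound 3 (2.46 log units; beyond the scatter), exchanges the aromatic ring on the carbon with a double bond to nitrogen, and was large. It does not touch the alkyl group on that carbon. For the measured compounds named here, no measured pair varies cyclopropyl against another alkyl group, so nothing here speaks directly to the change from compound 1 to compound 4. Without a bearing step, the expectation for compound 4 is a number close to that of compound 1, with no step beyond the scatter but a wide spread either way.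

Compound 4 is therefore estimated at 25000 nM, in the range 5000 nM to 100000 nM. This estimate means an expected step of a 1.2-fold higher number from compound 1 to compound 4 (0.08 log units; within the scatter).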

Compound 4, half-maximal inhibitory concentration: > 10000 nM
Compound 4: only a limit was reported; the forecaster's own chance of this, stated with the estimate: 25%; the middle value lies beyond the limit too.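

Compound 4 gives > 10000 nM, which is a limit of the assay and not a number. Set against compound 1, this limit yields no readable step for tert-butyl in place of cyclopropyl. The compounds shown leave open whether that exchange raises, lowers or leaves unchanged the number seen for compound 1.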